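The source may hold more compounds than are shown below. What is called first, only, known or untested is meant among the compounds shown, and "the series" means these compounds.

Compound 1 `CCOC(=O)CCCCCOc1cccc(CN(C(=O)c2ccc(-c3cccc(OC(C)C)c3)cc2)C(C)C)c1`: in an ADME assay on BJ cells (Homo sapiens) for cytotoxicity, read by CellTiter-Glo and resazurin assay, with a stated time of 72 h (on this read-out higher numbers stand for an effect only at larger amounts of compound and lower numbers for an effect already at smaller amounts), compound 1 gives > 26000 nM, which is a limit of the assay and not a number.
Compound 2 `CCOC(=O)CCCCCOc1cccc(CN(C(=O)c2ccc(-c3cc(OC)cc(OC)c3)cc2)C(C)C)c1`: in this assay compound 2 gives > 26000 nM, again a limit.
Compound 3 `CCOC(=O)CCCCCOc1cccc(CN(C(=O)c2ccc(-c3cccc(O)c3)cc2)C(C)C)c1`: in this assay compound 3 gives > 26000 nM, again a limit.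

Compound 3 therefore stands at the limit of this assay, and the two further values shown sit at the same limit (the limit of > 26000 nM in this assay, at which 3 of the 3 values shown sit). Going by the values given here, none of the measured steps can be read: a step that the two limits leave unreadable from compound 1 to compound 2, a step that the two limits leave unreadable from compound 1 to compound 3 and a step that the two limits leave unreadable from compound 2 to compound 3 all run between limits, so no size and no direction is known for any change at this part of the core.

Compound 4 `CCOC(=O)CCCCCOc1cccc(CN(C(=O)c2ccc(-c3cc(F)cc(OC)c3)cc2)C(C)C)c1` differs from compound 3 in one place: 3-fluoro-5-methoxyphenyl in place of 3-hydroxyphenyl on an aromatic carbon. Among the compounds with values here, no measured step bears on this change with a readable size, so no movement beyond the scatter is expected in this assay, and the step that the limit leaves unreadable from compound 3 to compound 4 is expected only as a further unreadable step between limits. For compound 4 the estimate in this assay is 40000 nM, with a range from 20000 nM to 100000 nM, and the expectation is that the assay again reports only its limit.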

Compound 4, half-maximal effective concentration: > 26000 nM
Compound 4 gave a limit, no number (the forecaster's own chance of this, stated with the estimate: 90%); the middle value lies beyond the limit too.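

In this assay compound 4 gives > 26000 nM, a limit and not a number. None of the steps from compound 1, compound 2 or compound 3 to compound 4 can be read. The compounds shown leave open whether any change at this part of the shared core gives a readable value in this assay.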